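Formyl for methyl on the aryl arm of compound 2

The source may report more compounds than this note shows. Statements on the series, on what has been measured and on what is new or still open speak of the compounds shown alone.

Compound 1 `O=Cc1ccc(-c2cn3ccnc3c(-c3ccc4ncn(C5CCCCC5)c4c3)n2)cc1` and compound 2 `Cc1cccc(-c2cn3ccnc3c(-c3ccc4ncn(Cc5ccccc5)c4c3)n2)c1` have been run in a functional assay on HCT-116 cells (Homo sapiens) for inhibition, read by sulforhodamine B assay, with a stated time of 48 h, tested at 10 uM; a higher number here means more inhibition at the concentration tested (going by the name of the read-out), a lower number less inhibition. In this assay compound 1 gives 92.6%, while compound 2 gives 36.7%, the lowest of the two numbers and a gap beyond the scatter. Among the measured compounds shown here, the two differ in two places, so no single step between them is known. Compound 3 `O=Cc1ccc(-c2cn3ccnc3c(-c3ccc4ncn(Cc5ccccc5)c4c3)n2)cc1` keeps the benzyl of compound 2, with 4-formylphenyl in place of 3-methylphenyl on an aromatic carbon. Compound 1 carries the same 4-formylphenyl and gives 92.6% in this assay. For compound 3 a rise beyond the scatter is expected, a number 33.3 percentage points higher from compound 2 to compound 3 (beyond the scatter). Compound 3 is estimated at 70%, range 40% to 95%.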

Compound 3, a percentage reported as inhibition, at one concentration (the size of the read-out at that concentration, not a potency): 92.6%
Compound 3: the middle estimate sits 22.6 percentage points below what was measured, within the range that was stated.
By their numbers in this assay, from the lowest: compound 2; then compounds 1 and 3 (each within the scatter of the next).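

In this assay the swap of 3-methylphenyl for 4-formylphenyl on the aromatic carbon gives a number 55.9 percentage points higher from compound 2 to compound 3 (beyond the scatter) with the benzyl held constant, so this change alone carries a large step. With 4-formylphenyl held, the swap of cyclohexyl for benzyl on the aromatic nitrogen gives no change at the digits printed from compound 1 to compound 3 (within the scatter) in the same assay. Nothing on hand bears on the reason for either step.

Still open, as far as these compounds go, is whether the step belongs to the formyl itself or to its 4-position on the phenyl ring, since the methyl sits at the 3-position. From the compounds shown here alone, how a 4-carboxylic acid or a 4-aminomethyl group would read at this place also remains open.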